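The source may report more compounds than this note shows. Statements on the series, on what has been measured and on what is new or still open speak of the compounds shown alone.

Measured compounds in a functional assay on HCT-116 cells (Homo sapiens) for cytotoxicity, read by MTT assay, with a stated time of 48 h; on this read-out higher numbers stand for weaker inhibition and lower numbers for stronger inhibition:
compound 1 `CCN(CC)c1ccc2cc(C(=O)c3ccc(N4CCN(C(=O)CN5CCNCC5)CC4)cc3)oc2c1`, 1870 nM
compound 2 `C#CCN1CCN(CC(=O)N2CCN(c3ccc(C(=O)c4cc5ccc(N(CC)CC)cc5o4)cc3)CC2)CC1`, 17700 nM

Compound 2 stands at the higher, weaker end of these two numbers. Among the compounds with values here, the only measured step runs a 9.5-fold higher number from compound 1 to compound 2 (0.98 log units; beyond the scatter), a propargyl in place of hydrogen on the amine nitrogen of the terminal ring. Compound 3 `CCN(CC)c1ccc2cc(C(=O)c3ccc(N4CCN(C(=O)CN5CCN(Cc6ccc(/C=C/C(=O)OC)cc6)CC5)CC4)cc3)oc2c1` keeps that substituted nitrogen but carries 4-(2-(methoxycarbonyl)ethenyl)phenyl in place of ethynyl on a saturated chain carbon bound to an amine nitrogen in a ring. Within the data shown here, no measured pair shows this kind of exchange, so the single step gives only indirect guidance: putting a group on that ring nitrogen made the number higher once, and whether a much larger group with an aromatic ring and a methoxycarbonyl part would push it further or partly reverse it cannot be read from these data. The expected outcome for compound 3 is therefore a step of a 1.5-fold lower number from compound 2 to compound 3 (0.17 log units; within the scatter), close to no change, and the estimate for compound 3 is 12000 nM with a range from 2500 nM to 50000 nM.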

Compound 3, half-maximal inhibitory concentration: 9920 nM
Compound 3: the middle estimate sits 1.2-fold (0.08 log units) above what was measured; measured number inside the range.
By their numbers in this assay, from the lowest: compound 1; then compounds 3 and 2 (each within the scatter of the next).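

Exchanging ethynyl for 4-(2-(methoxycarbonyl)ethenyl)phenyl on a saturated chain carbon bound to an amine nitrogen in a ring gives a 1.8-fold lower number from compound 2 to compound 3 (0.25 log units; within the scatter) in this assay, so the two compounds cannot be told apart on this read-out. This position therefore carries a much larger end group, with an aromatic ring and 2 hydrogen-bond acceptors, and the number stays within the scatter of the one seen with the small ethynyl end. Nothing available explains why so large an exchange leaves the number this close.

Still open, on these data alone, is which part of the new group matters, and a plain benzyl group on that nitrogen would help to separate the aromatic ring from the ester end. A carboxylic acid in place of the methyl ester would test that end on its own.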